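A few compounds are considered here, and "the series" means these few. Any claim that something is new, unique, unknown or untested is made for them only; others in the source may bear on it.

In a functional assay on KYSE-450 cells (Homo sapiens) for inhibition, read by MTT assay, with a stated time of 48 h (a lower number here means a stronger inhibitor, a higher number a weaker inhibitor), compound 1 `COc1ccc(CNc2cc(OC)c(OC)c(OC)c2)cc1[N+](=O)[O-]` gives 16800 nM, and compound 2 `COc1ccc(CNc2cc(OC)c(OC)c(OC)c2)cc1Br` gives 39800 nM. Putting bromo in place of nitro on an aromatic carbon is thus a 2.4-fold higher number from compound 1 to compound 2 (0.37 log units; beyond the scatter), a modest step. Compound 3 `C/C=C/C(=O)N(Cc1ccc(OC)c(C)c1)c1cc(OC)c(OC)c(OC)c1` gives 32900 nM in this assay, a number within the scatter of both the others.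

Compound 4 `COc1ccc(CNc2cc(OC)c(OC)c(OC)c2)cc1C` comes from compound 3 by a single structural change: hydrogen in place of (prop-1-en-1-yl)carbonyl on a nitrogen on an aromatic ring. In words, hydrogen takes the place of (prop-1-en-1-yl)carbonyl on a nitrogen on an aromatic ring. Compound 4 therefore has hydrogen on this nitrogen, as compound 1 and compound 2 do.

Among the compounds with values here, no measured step removes this group, and the data give no direct size for the change. Within the data shown here, the only measured step, a 2.4-fold higher number from compound 1 to compound 2 (0.37 log units; beyond the scatter), concerns a different place in the structure and bears on this change only indirectly. It suggests that compounds with hydrogen on this nitrogen can differ modestly. Compound 3, at 32900 nM, already sits among their numbers, so no step beyond the scatter is expected in this assay, though this is a weakly supported expectation.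

The expected change is a 1.2-fold lower number from compound 3 to compound 4 (0.07 log units; within the scatter). Compound 4 is estimated at 28000 nM, with an expected range from 11000 nM to 70000 nM.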

Compound 4, half-maximal inhibitory concentration: 73800 nM
Estimate against measurement, compound 4: 2.6-fold (0.42 log units) below, outside the stated range (above it).
By their numbers in this assay, from the lowest: compounds 1, 3, 2 and 4 (each within the scatter of the next, the first and the last beyond it).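

Taking the (prop-1-en-1-yl)carbonyl off the nitrogen is a 2.2-fold higher number from compound 3 to compound 4 (0.35 log units; beyond the scatter) in this assay, a modest step and the first one shown at this nitrogen, with the compound that carries the group giving the lower number. The same compound also links the earlier pair to a methyl group on the aromatic carbon: bromo and methyl cannot be told apart, with a 1.9-fold higher number from compound 2 to compound 4 (0.27 log units; within the scatter), whereas nitro and methyl can, with a 4.4-fold higher number from compound 1 to compound 4 (0.64 log units; beyond the scatter). Nothing measured here explains either the effect at the nitrogen or the difference at the aromatic carbon.

As far as these compounds go, the step at the nitrogen is read only on the compound with methyl on the aromatic carbon, so it remains open whether the same group would shift the number similarly with nitro or bromo there. Also open, from the compounds shown here alone, is which part of the group matters, a question that an acetyl or a saturated butanoyl group on this nitrogen would address, while an amine or a carboxylic acid on the aromatic carbon would test that position further.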